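Moving a Methyl Around a Saturated Ring

The compounds below may be only part of what the source reports. "The series", "measured", "known", "first", "only" and "open" are said of these compounds alone.

Of the compounds shown here, three built on one shared core have been tested in a functional assay on the whole organism for inhibition, with Rattus norvegicus as the target; a lower number here means that less compound is needed, a higher number that more compound is needed for the effect. Compound 1 `CC1CC/C(=N\Nc2ccccc2)c2ncc(C(N)=O)c(=O)n21` carries a carboxamide and reaches only a limit of > 1000 umol/kg. Compound 2 `CC1CCC(=NNc2ccccc2)c2ncc(C(=O)O)c(=O)n21` carries a carboxylic acid in place of that carboxamide together with a methyl on the six-membered non-aromatic ring, and in this assay compound 2 gives 1.2 umol/kg. Compound 3 `O=C(O)c1cnc2n(c1=O)CCC/C2=N\Nc1ccccc1` keeps the carboxylic acid but has no methyl on that ring, and in this assay compound 3 reaches only a limit of > 100 umol/kg. Compound 3 therefore sits at the limit of > 100 umol/kg in this assay, at which 1 of the 3 values shown sits, while compound 1 sits at the limit of > 1000 umol/kg in this assay, at which 1 of the 3 values shown sits; only compound 2 yields a number.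

Compound 4 `CC1C/C(=N\Nc2ccccc2)c2ncc(C(=O)O)c(=O)n2C1` is not yet measured. It differs from compound 3 by methyl in place of hydrogen on a saturated ring carbon. Compound 2 shows that a methyl on the saturated ring can go together with a much lower dose than the limit seen for compound 3, although the methyl of compound 4 sits at a different carbon of that ring, so the change is expected to lower the dose, yet with wide uncertainty. Compound 4 is expected to give about 10 umol/kg, with a likely range from 1 umol/kg to 150 umol/kg. That estimate corresponds to an expected step of an at least 10-fold lower number from compound 3 to compound 4 (1.00 log units; beyond the scatter).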

Compound 4, dose for 50% inhibition: > 320 umol/kg
Compound 4 gave a limit, no number; the forecaster's own chance of this, stated with the estimate: 30%; middle value at least 32-fold (1.50 log units) from the limit.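

In this assay compound 4 gives only a limit, > 320 umol/kg. Compound 3 also gives only a limit, > 100 umol/kg. With limits on both sides, the step between compound 3 and compound 4 cannot be read. The compounds shown leave open whether a methyl on this saturated ring carbon changes the dose needed at all.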